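A few compounds are considered here, and "the series" means these few. Any claim that something is new, unique, unknown or untested is made for them only; others in the source may bear on it.

Values measured in a functional assay on PC-3 cells (Homo sapiens) for inhibition, read by sulforhodamine B assay, with a stated time of 48 h, tested at 50 uM (on this read-out lower numbers stand for less inhibition of growth and higher numbers for more inhibition of growth at the one concentration tested), are as follows:

- compound 1 `CCCOc1ccc([C@@H]2CC(=O)c3cc(CC=C(C)C)c(OC)cc3O2)cc1` gives 54%
- compound 2 `COc1cc2c(cc1CC=C(C)C)C(=O)C[C@@H](c1ccc(Oc3ccc(F)cc3)cc1)O2` gives 19%
- compound 3 `COc1ccc([C@@H]2C/C(=N/OCc3cn(-c4ccc(Cl)cc4C)nn3)c3cc(CC=C(C)C)c(OC)cc3O2)cc1` gives 49%

Compound 2 stands lowest of these three numbers and lies beyond the scatter from both others, with compound 3 the nearest. The change to compound 4 `CCCCOc1ccc([C@@H]2CC(=O)c3cc(CC=C(C)C)c(OC)cc3O2)cc1` puts butyl in place of 4-fluorophenyl on an oxygen on an aromatic ring. Within the data shown here, one measured step bears on this: a number 35 percentage points lower from compound 1 to compound 2 (beyond the scatter) was large and beyond the scatter, with 4-fluorophenyl in place of propyl at that same place. Among the measured compounds shown here, no step in a single place links compound 3 to the others, and no butyl compound has yet been measured. The change nearly reverses that step, so a rise of similar size, beyond the scatter, is expected in this assay (estimated as a number 31 percentage points higher from compound 2 to compound 4 (beyond the scatter)). This expectation rests on compound 1 with its propyl group (54%). Compound 4 is therefore estimated at 50% (expected range 35% to 65%).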

Compound 4, percent growth inhibition at one concentration: 48%
Estimate against measurement, compound 4: 2 percentage points above; the measured number falls inside the stated range.
By their numbers in this assay, from the lowest: compound 2; then compounds 4, 3 and 1 (each within the scatter of the next).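

In this assay, the result gives a second chain at this place on the oxygen on an aromatic ring, and a number 29 percentage points higher from compound 2 to compound 4 (beyond the scatter) shows butyl in place of 4-fluorophenyl. Propyl and butyl cannot be told apart here, as a number 6 percentage points lower from compound 1 to compound 4 (within the scatter) is the step for the added methyl on the chain. Both chains therefore stand apart from the 4-fluorophenyl group of compound 2 on the same core, so the low number of compound 2 goes with that group and not with the core.

No measurement available gives a reason for this difference. From the compounds shown here alone, whether the ring or its fluorine goes with the low number stays open, as does the outcome with an unsubstituted phenyl, a longer chain such as hexyl, or a chain ending in an amine.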